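Shifting the methoxy group: compound 3 to compound 4

This account rests on a few compounds, and the source may have more. Where it says the series, first, only, none or still open, it means among the compounds named here.

Measured in a functional assay on L1210 cells (Mus musculus) for antiproliferative activity, read by MTT assay, with a stated time of 72 h; a lower number here means a stronger inhibitor, a higher number a weaker inhibitor:
- compound 1 `COc1cc(C2=NN(C(C)=O)C(c3ccc([N+](=O)[O-])cc3)O2)cc(OC)c1OC`: 4200 nM
- compound 2 `COc1cc(C2=NN(C(C)=O)C(c3cccc([N+](=O)[O-])c3)O2)cc(OC)c1OC`: 39000 nM
- compound 3 `COc1ccc(C2OC(c3cc(OC)c(OC)c(OC)c3)=NN2C(C)=O)cc1`: 57000 nM

Compound 3 sits at the weak end of this small set, level with its nearest neighbour: a 1.5-fold higher number from compound 2 to compound 3 (0.16 log units; within the scatter). The gap to the remaining member is larger: a 14-fold higher number from compound 1 to compound 3 (1.13 log units; beyond the scatter).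

Compound 4 `COc1cccc(C2OC(c3cc(OC)c(OC)c(OC)c3)=NN2C(C)=O)c1` differs from it by 3-methoxyphenyl in place of 4-methoxyphenyl on a saturated ring carbon. Going by the values given here, the closest precedent is the matching move among the nitrophenyl compounds, a 9.3-fold higher number from compound 1 to compound 2 (0.97 log units; beyond the scatter). That move started from the much stronger compound 1 and involved nitro rather than methoxy, so it transfers poorly to compound 3. In this assay no step beyond the scatter is therefore expected. The estimate means a 1.1-fold lower number from compound 3 to compound 4 (0.06 log units; within the scatter), an expected step within the scatter. Compound 4 is estimated at 50000 nM, with an expected range of 15000 nM to 150000 nM.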

Compound 4, half-maximal inhibitory concentration: 45000 nM
For compound 4 the middle estimate is 1.1-fold (0.05 log units) above the measured one; the measured number falls inside the stated range.
By their numbers in this assay, from the lowest: compound 1; then compounds 2, 4 and 3 (each within the scatter of the next).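

In this assay, moving the methoxy group around the phenyl ring changes little, a 1.3-fold lower number from compound 3 to compound 4 (0.10 log units; within the scatter), whereas the matching shift of the nitro group gave a step beyond the scatter. Set against the nitrophenyl compounds, the 3-methoxyphenyl group is level with 3-nitrophenyl, a 1.2-fold higher number from compound 2 to compound 4 (0.06 log units; within the scatter), but not with 4-nitrophenyl, an 11-fold higher number from compound 1 to compound 4 (1.03 log units; beyond the scatter). The size of the swap from nitro to methoxy thus depends on where the group stands on the phenyl ring: the same change on two cores in this assay, a 14-fold higher number (1.13 log units; beyond the scatter) from compound 1 to compound 3 and a 1.2-fold higher number (0.06 log units; within the scatter) from compound 2 to compound 4, 12-fold (1.07 log units) apart, beyond the scatter of two such steps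

The compounds shown leave open whether the low number of compound 1 belongs to nitro alone. A nitrile or a carboxylic acid in that place could answer this.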